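Two Diiodophenol Hydrazide Pairs Sharing One Aromatic Substituent Swap

A few compounds are considered here, and "the series" means these few. Any claim that something is new, unique, unknown or untested is made for them only; others in the source may bear on it.

Measured so far:
Compound 1 `O=C(N/N=C/c1cc(I)c(O)c(I)c1)c1ccc(C(F)(F)F)cc1` gives 57400 nM in a functional assay on HepG2 cells (Homo sapiens) for cytotoxicity, with a stated time of 24 h; on this read-out lower numbers stand for stronger inhibition and higher numbers for weaker inhibition.
Compound 2 `O=C(N/N=C/c1cc(I)c(O)c(I)c1)c1ccc([N+](=O)[O-])cc1` gives 92100 nM in this assay.
Compound 3 `O=C(NNC(=O)c1cc(I)cc(I)c1O)c1ccc(C(F)(F)F)cc1` gives 167000 nM in this assay.

Compounds 1 and 2 share one core; the change between them is nitro in place of trifluoromethyl on an aromatic carbon and it produced a 1.6-fold higher number from compound 1 to compound 2 (0.21 log units; within the scatter). Compound 3 carries a different core, and the difference between the two cores is not broken down here. Compound 4 `O=C(NNC(=O)c1cc(I)cc(I)c1O)c1ccc([N+](=O)[O-])cc1` is not yet measured. It relates to compound 3 exactly as compound 2 relates to compound 1: the change is nitro in place of trifluoromethyl on an aromatic carbon, the same change, made at the same place. Because the earlier step gave a 1.6-fold higher number from compound 1 to compound 2 (0.21 log units; within the scatter), the step from compound 3 to compound 4 is expected to be of similar size, about a 1.6-fold higher number from compound 3 to compound 4 (0.21 log units; within the scatter). Compound 4 is therefore estimated at 270000 nM, expected to lie between 120000 nM and 600000 nM.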

Compound 4, half-maximal inhibitory concentration: 159000 nM
For compound 4 the middle estimate is 1.7-fold (0.23 log units) above the measured one; the range from low to high includes it.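

On the core of compound 3, nitro in place of trifluoromethyl gave a 1.1-fold lower number from compound 3 to compound 4 (0.02 log units; within the scatter) in this assay. Set beside the earlier step, the change behaves alike on the two cores: the same change on two cores in this assay, a 1.6-fold higher number (0.21 log units; within the scatter) from compound 1 to compound 2 and a 1.1-fold lower number (0.02 log units; within the scatter) from compound 3 to compound 4, 1.7-fold (0.23 log units) apart, within the scatter of two such steps. Among the compounds shown here, this shows only that the change stayed within the scatter on both cores in this one cytotoxicity read-out; it does not show that the change has any real effect that carries over, and two pairs set no rule for other cores.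

The compounds shown leave open what an amine, a carboxylic acid or a longer chain would do at the same place on the aromatic ring. On these data alone, what chlorine in place of iodine would do on either core also remains open.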